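Chlorine on the Thiophene: What Cytotoxicity to Expect

A few compounds are considered here, and "the series" means these few. Any claim that something is new, unique, unknown or untested is made for them only; others in the source may bear on it.

Compound 1, `O=C(/C=C/c1ccc(N2CCCCC2)cc1)c1cccs1`: > 100000 nM
Compound 2, `c1cc(C2=NNC(c3ccc(N4CCCCC4)cc3)C2)cs1`: > 100000 nM

Of the compounds shown here, two have been tested in an ADME assay on PBMC cells (Homo sapiens) for cytotoxicity, with a stated time of 5 days; on this read-out lower numbers stand for stronger inhibition and higher numbers for weaker inhibition. In this assay compound 1 gives > 100000 nM, which is a limit of the assay and not a number. In this assay compound 2 gives > 100000 nM, again a limit rather than a number. Where compound 2 stands is therefore known only as a bound: it sits at the limit of > 100000 nM in this assay, at which 2 of the 2 values shown sit. With both values capped in this way, no order between the two compounds can be read, and no step size has been measured.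

Compound 3, `Clc1ccsc1C1=NNC(c2ccc(N3CCCCC3)cc2)C1`, differs from compound 2 in one place: 3-chlorothiophen-2-yl in place of thiophen-3-yl on a carbon with a double bond to nitrogen. For the measured compounds named here, there is no measured step in this assay that resembles this change, so the expectation rests only on the fact that every value so far has been a limit. The expected step is a step that the limit leaves unreadable from compound 2 to compound 3, that is, none beyond the usual scatter, with compound 3 most likely reported once more as a limit. The estimate for compound 3 in this assay is 150000 nM, with a range from 50000 nM to 500000 nM.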

Compound 3, half-maximal inhibitory concentration: 34200 nM
The estimate for compound 3 lay 4.4-fold (0.64 log units) above the measured number, and the stated range ends above it.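

In this assay, for the compounds shown here, this position turns out not to be silent: replacing thiophen-3-yl with 3-chlorothiophen-2-yl on a carbon with a double bond to nitrogen produces the first real number, with an at least 2.9-fold lower number from compound 2 to compound 3 (0.46 log units; beyond the scatter) as the step. The earlier compounds shown here could not show this, as neither of their results gave any sign that a change to the shared core could shift the read-out. The true size of the step may be larger than the printed figure, because compound 2 gives only a limit and not a number: the limit of > 100000 nM in this assay, at which 2 of the 3 values shown sit.

This single change does two things at once, adding a chlorine and moving the attachment point on the thiophene from the 3-position to the 2-position, and the compounds shown leave open which of the two, or what combination of them, accounts for the step. A plain thiophen-2-yl group would separate these two parts, while a bromine atom or a methyl group in place of the chlorine would test whether the chlorine itself is needed.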